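The source may hold more compounds than are shown below. What is called first, only, known or untested is meant among the compounds shown, and "the series" means these compounds.

Measured so far:
Compound 1, `CC(C)(C)Cc1c(/C=C/c2ccc(Cl)cc2)sc(N)c1C(=O)c1ccc(Cl)cc1`: 11%
Compound 2, `CC(C)(C)Cc1c(-c2ccc(Cl)c(Cl)c2)sc(N)c1C(=O)c1ccc(Cl)cc1`: 1%

Compound 2 gives the lowest of the two numbers in an assay on CHO cells for displacement of a labelled ligand from adenosine receptor A3 (Homo sapiens), read by scintillation counting, tested at 10 uM; on this read-out higher numbers stand for more inhibition at the one concentration tested (going by the name of the read-out) and lower numbers for less inhibition. For the measured compounds named here, its nearest neighbour is compound 1, and the single step between them, a number 10 percentage points lower from compound 1 to compound 2 (within the scatter), lies within the scatter of repeated measurements, so the two compounds cannot be told apart on this read-out.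

Compound 3, `CC(C)(C)Cc1c(-c2ccsc2)sc(N)c1C(=O)c1ccc(Cl)cc1`, is the next compound in this series. It differs from compound 2 in one place: thiophen-3-yl in place of 3,4-dichlorophenyl on an aromatic carbon.

Going by the values given here, only one measured step touches the same position, the replacement of the ethenyl-linked aryl group by the dichlorinated phenyl group from compound 1 to compound 2, and that step stayed within the scatter. Among the compounds with values here, nothing measured so far shows that a change at this position moves the number beyond the noise. The step from compound 2 to compound 3 is therefore expected to be small, a number 5 percentage points higher from compound 2 to compound 3 (within the scatter), with no direction that can be called. Compound 3 is estimated to give 6% in this assay, most likely between -6% and 22%.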

Compound 3, a percentage reported as inhibition, at one concentration (the size of the read-out at that concentration, not a potency): 4%
For compound 3 the middle estimate is 2 percentage points above the measured one; measured number inside the range.
By their numbers in this assay, from the lowest: compounds 2, 3 and 1 (each within the scatter of the next).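

In this assay, thiophen-3-yl in place of 3,4-dichlorophenyl gives a number 3 percentage points higher from compound 2 to compound 3 (within the scatter), and thiophen-3-yl in place of 2-(4-chlorophenyl)ethenyl gives a number 7 percentage points lower from compound 1 to compound 3 (within the scatter). The position on the aromatic carbon next to the ring sulfur now carries three different aromatic groups, one of them a five-membered ring with a sulfur atom, and every step among them stays within the scatter, so neither the loss of both chlorines nor the smaller ring can be told apart from noise on this read-out. No supporting data are available to explain this flat result.

On these data alone, whether an amine or a carboxylic acid at this position would move the number beyond the scatter stays open. So does whether replacing the neopentyl group or the (4-chlorophenyl)carbonyl group would do so.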